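Aryl Exchange on the Ring Nitrogen of Compound 2

The source may report more compounds than this note shows. Statements on the series, on what has been measured and on what is new or still open speak of the compounds shown alone.

Compound 2 `Cc1cccc(N2CCN(c3nc(C(F)(F)F)ccc3CNC(=O)C(C)c3ccc(NS(C)(=O)=O)c(F)c3)CC2)c1` gives 3.4 nM in a functional assay on CHO-K1 cells for antagonist activity at transient receptor potential cation channel subfamily V member 1 (Homo sapiens), read by FLIPR (a lower number here means a stronger inhibitor, a higher number a weaker inhibitor), the lowest of the two numbers measured; its nearest neighbour, compound 1 `CC(C(=O)NCc1ccc(C(F)(F)F)nc1N1CCN(C)CC1)c1ccc(NS(C)(=O)=O)c(F)c1`, gives 146 nM, and the step of a 43-fold lower number from compound 1 to compound 2 (1.63 log units; beyond the scatter) lies beyond the scatter. Compound 3 `COc1ccc(N2CCN(c3nc(C(F)(F)F)ccc3CNC(=O)C(C)c3ccc(NS(C)(=O)=O)c(F)c3)CC2)cc1` differs from compound 2 by 4-methoxyphenyl in place of 3-methylphenyl on an amine nitrogen in a ring. Among the compounds with values here, no measured step exchanges one aryl group for another at this place; the only measured step there replaces methyl with an aryl group, so it bears on this change only loosely. A step within the scatter is therefore expected for compound 3, a 1.5-fold higher number from compound 2 to compound 3 (0.17 log units; within the scatter). Compound 3 is estimated at 5 nM, within 1.5 nM to 20 nM.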

Compound 3, inhibition constant: 2.5 nM
Compound 3: middle estimate off by 2.0-fold (0.30 log units), on the high side, and the stated range covers the measured number.
By their numbers in this assay, from the lowest: compounds 3 and 2 (each within the scatter of the next); then compound 1.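

In this assay, exchanging one aryl group for another on the amine nitrogen in a ring stays within the scatter, with a 1.4-fold lower number from compound 2 to compound 3 (0.13 log units; within the scatter), so 3-methylphenyl and 4-methoxyphenyl cannot be told apart at this position. The large fall in the number from methyl recurs with a second aryl group, at a 58-fold lower number from compound 1 to compound 3 (1.77 log units; beyond the scatter), so it is not confined to 3-methylphenyl. Nothing at hand bears on the cause of either step. The compounds shown leave open whether a pyridine ring or a benzyl group on this nitrogen would keep the number as low as the two aryl groups do.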